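The source may report more compounds than this note shows. Statements on the series, on what has been measured and on what is new or still open speak of the compounds shown alone.

Measured so far in a functional assay on K562 cells (Homo sapiens) for inhibition, read by trypan blue exclusion, with a stated time of 72 h (on this read-out lower numbers stand for stronger inhibition and higher numbers for weaker inhibition), are two compounds
Compound 1 `COC(=O)Cn1c(=O)c(S(=O)(=O)c2ccc(F)cc2F)cc2cnc(Nc3ccc4[nH]ccc4c3)nc21` gives 5000 nM
Compound 2 `O=c1c(S(=O)(=O)c2ccc(F)cc2F)cc2cnc(Nc3ccc4[nH]ccc4c3)nc2n1CC1CCCC1` gives 7000 nM

In this assay compound 2 at 7000 nM stands within the scatter of compound 1 and so holds no distinct place on these two numbers. Compound 3 `O=c1c(S(=O)(=O)c2ccc(F)cc2F)cc2cnc(Nc3ccc4[nH]ccc4c3)nc2n1CC1CC1` differs from compound 2 by cyclopropyl in place of cyclopentyl on a saturated chain carbon bound to an aromatic nitrogen which amounts to cyclopropyl in place of cyclopentyl on a saturated chain carbon bound to an aromatic nitrogen. Among the measured compounds shown here, one measured step bears on this place, a 1.4-fold higher number from compound 1 to compound 2 (0.15 log units; within the scatter) and it lies within the scatter. For the measured compounds named here, no step between two carbon rings has been measured. On that single step the expected change is a 1.2-fold lower number from compound 2 to compound 3 (0.07 log units; within the scatter) which means none beyond the scatter and no firm direction. For compound 3 the estimated value is 6000 nM with 2500 nM to 14000 nM as the expected range.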

Compound 3, half-maximal inhibitory concentration: 1000 nM
Compound 3: the middle estimate sits 6.0-fold (0.78 log units) above what was measured; the measured number lies below the stated range.
By their numbers in this assay, from the lowest: compound 3; then compounds 1 and 2 (each within the scatter of the next).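

In this assay, among the compounds shown here, the group on a saturated chain carbon bound to an aromatic nitrogen now moves the number beyond the scatter: cyclopropyl in place of cyclopentyl gives the largest step so far (a 7.0-fold lower number from compound 2 to compound 3 (0.85 log units; beyond the scatter)), whereas the earlier step stayed within it. Cyclopropyl in place of methoxycarbonyl points the same way (a 5.0-fold lower number from compound 1 to compound 3 (0.70 log units; beyond the scatter)), so compound 3 stands apart from compound 1 and compound 2, which remain within the scatter of each other. Nothing measured here explains this difference.

Open, from the compounds shown here alone, is how cyclobutyl, a plain ethyl group, an amine or a carboxylic acid at this place would read, so it cannot yet be said whether the three-membered ring itself matters. Also open, going by these compounds, is whether cyclopropyl would give a step of this size with other changes elsewhere on the shared core.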